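The source may hold more compounds than are shown below. What is called first, only, known or untested is meant among the compounds shown, and "the series" means these compounds.

Compound 1, `O=C(NCc1ccc(S(=O)(=O)N2CCCCC2)cc1)c1cc2cnccc2s1`, gives 15% in an ADME assay on microsomes from liver (Homo sapiens) for metabolic stability, read by LC-MS, with a stated time of 30 min, tested at 1 uM; a higher number here means that more of the compound is left, a lower number that less of the compound is left.
Compound 2, `O=C(NCc1ccc(S(=O)(=O)c2ccccc2C(F)(F)F)cc1)c1cc2cnccc2[nH]1`, gives 52%.
Compound 3, `O=C(NCc1ccc(S(=O)(=O)c2ccccc2)cc1)c1ccc2cnccc2c1`, gives 31%.

Among these three, compound 1 stands lowest in this assay: the nearest number, that of compound 3, lies higher by a margin beyond the usual scatter, and the number of compound 2 lies higher still, also beyond the scatter. So of the three, compound 1 is the one of which the least remains after the stated time.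

Compound 4, `O=C(NCc1ccc(S(=O)(=O)N2CCCCC2)cc1)c1cc2cccnc2s1`, has not yet been measured in this assay. It differs from compound 1 in one place only, and the two have the same atoms, joined differently:

a group of 9 heavy atoms (7 carbon, 1 nitrogen, 1 sulfur; one five-membered aromatic ring with 1 hetero atom, one six-membered aromatic ring with 1 hetero atom) in place of a group of 9 heavy atoms (7 carbon, 1 nitrogen, 1 sulfur; one five-membered aromatic ring with 1 hetero atom, one six-membered aromatic ring with 1 hetero atom), on a carbonyl carbon

The exchange sits on the carbonyl carbon whose other neighbour is the amide-type nitrogen; everything on the other side of the amide is unchanged. Going by the values given here, no pair of measured compounds differs by this kind of exchange alone, so there is no comparison of the same kind to lean on. Given that the group leaving and the group entering match in every count given, the step from compound 1 to compound 4 is expected to be small, within the scatter, with no clear direction. Compound 4 is therefore estimated at 20%, in a range from 8% to 40%, which means an expected step of a number 5 percentage points higher from compound 1 to compound 4 (within the scatter).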

Compound 4, percent of the compound remaining: "below limit of detection" (no number reported)
Nothing numeric was reported for compound 4; the estimate stays without a comparison.
By their numbers in this assay, from the lowest: compound 1; then compound 3; then compound 2.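

Going by these compounds alone, compound 4 gives no number in this assay, only the report "below limit of detection", so no step from compound 1 to compound 4 can be read. The compounds shown leave open how large the effect of this exchange on the carbonyl carbon is. No measurement shown here offers an explanation for this result.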